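Swapping one fluorinated ring on compound 3

The source may hold more compounds than are shown below. What is called first, only, known or untested is meant among the compounds shown, and "the series" means these compounds.

Going by the values given here, in a functional assay on HepG2 cells (Homo sapiens) for antiproliferative activity, read by sulforhodamine B assay, with a stated time of 48 h (a lower number here means a stronger inhibitor, a higher number a weaker inhibitor), compound 3 (`COc1ccc(C(=O)/C=C/c2ccccc2-c2ccc(F)cc2)cc1O`) gives 190 nM, the lowest number so far and beyond the scatter of the other two. Compound 1 (`COc1ccc(C(=O)/C=C/c2ccccc2-c2ccc(F)nc2)cc1`) gives 8200 nM, and compound 2 (`O=C(/C=C/c1ccccc1-c1ccc(F)nc1)c1cccc(O)c1`) gives 6400 nM.

Compound 4 (`COc1ccc(C(=O)/C=C/c2ccccc2-c2ccc(F)nc2)cc1O`) has not yet been measured. It has 6-fluoropyridin-3-yl in place of 4-fluorophenyl on an aromatic carbon. Among the compounds with values here, no measured step isolates this swap. The only one available, a 1.3-fold lower number from compound 1 to compound 2 (0.11 log units; within the scatter), changes the group on the carbonyl carbon instead and stays within the scatter.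

Compound 1 and compound 2 do carry the incoming 6-fluoropyridin-3-yl, but each has only the methoxy or the hydroxy, while compound 3 and compound 4 have both. Their high numbers therefore cannot be pinned on the swap alone, so only a moderate rise is expected. The estimated change is a 2.1-fold higher number from compound 3 to compound 4 (0.32 log units; beyond the scatter). For compound 4 the expected value is 400 nM, within an estimated range of 100 nM to 2500 nM.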

Compound 4, half-maximal inhibitory concentration: 1800 nM
The estimate for compound 4 lay 4.5-fold (0.65 log units) below the measured number; measured number inside the range.
By their numbers in this assay, from the lowest: compound 3; then compound 4; then compounds 2 and 1 (each within the scatter of the next).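

In this assay, going by these compounds alone, this is the first step that isolates the ring at this position: with the rest of the molecule unchanged, 6-fluoropyridin-3-yl in place of 4-fluorophenyl gives a 9.5-fold higher number from compound 3 to compound 4 (0.98 log units; beyond the scatter) and so by itself weakens the compound. The ring nitrogen does not account for the whole gap to the earlier compounds, since with 6-fluoropyridin-3-yl kept, adding methoxy gives a 3.6-fold lower number from compound 2 to compound 4 (0.55 log units; beyond the scatter) and adding hydroxy gives a 4.6-fold lower number from compound 1 to compound 4 (0.66 log units; beyond the scatter), so both groups on the other ring also count here. Nothing available explains why either change shifts the number.

Still open, from the compounds shown here alone, is what a chloro group in place of the fluorine on this ring would do. The compounds shown also leave unsettled whether the ring swap costs as much without the methoxy or the hydroxy, as neither compound 1 nor compound 2 has a 4-fluorophenyl partner.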